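A few compounds are considered here, and "the series" means these few. Any claim that something is new, unique, unknown or untested is made for them only; others in the source may bear on it.

Measured compounds:
- compound 1, `CCOc1ccc(-c2ccc3ncn(-c4cc(OC)c(OC)c(OC)c4)c3c2)cc1`: 8550 nM
- compound 2, `COc1cc(-n2cnc3ccc(-c4ccccc4)cc32)cc(OC)c1OC`: 3060 nM
- compound 3, `COc1cc(-n2cnc3ccc(-c4ccc(C(F)(F)F)cc4)cc32)cc(OC)c1OC`: 3390 nM

All three share one core and differ only in the group on the outer aromatic ring. In a functional assay on A549 cells (Homo sapiens) for antiproliferative activity, read by MTT assay, with a stated time of 72 h (on this read-out lower numbers stand for stronger inhibition and higher numbers for weaker inhibition), compound 3 gives the second highest of the three numbers; its nearest neighbour is compound 2, and the two lie within the usual scatter of each other, while compound 1 stands clearly apart with a 2.5-fold lower number from compound 1 to compound 3 (0.40 log units; beyond the scatter).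

Compound 4, `COc1cc(-n2cnc3ccc(-c4ccc(Cl)cc4)cc32)cc(OC)c1OC`, is the next step from compound 3: chloro in place of trifluoromethyl on an aromatic carbon. Within the data shown here, two measured steps bear on this. The change from hydrogen to trifluoromethyl on that same aromatic carbon gave a 1.1-fold higher number from compound 2 to compound 3 (0.04 log units; within the scatter), so swapping one small group for another at this position has so far left this assay unmoved; only the ethoxy of compound 1 stood out, with a 2.8-fold lower number from compound 1 to compound 2 (0.45 log units; beyond the scatter). Chloro is a single heavy atom, closer in size to hydrogen than to ethoxy, so the expected step is a 1.1-fold lower number from compound 3 to compound 4 (0.03 log units; within the scatter), nothing beyond the scatter. Compound 4 is therefore estimated at 3200 nM, within 1500 nM to 7000 nM.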

Compound 4, half-maximal inhibitory concentration: > 10000 nM
Compound 4: a limit, no number; the forecaster's own chance of this, stated with the estimate: 2%; at least 3.1-fold (0.49 log units) between middle value and limit.
By their numbers in this assay, from the lowest: compounds 2 and 3 (each within the scatter of the next); then compound 1. At a limit, above all of these: compound 4.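

In this assay compound 4 gives > 10000 nM, a limit of the assay and not a number: the limit of > 10000 nM in this assay, at which 1 of the 4 values shown sits. This position is therefore not indifferent to a small group, even though the change from hydrogen to trifluoromethyl gave a 1.1-fold higher number from compound 2 to compound 3 (0.04 log units; within the scatter): chloro gives an at least 2.9-fold higher number from compound 3 to compound 4 (0.46 log units; beyond the scatter) and an at least 3.2-fold higher number from compound 2 to compound 4 (0.51 log units; beyond the scatter), so a single heavy atom in this place can clearly weaken the result. Against ethoxy, chloro gives an at least 1.1-fold higher number from compound 1 to compound 4 (0.06 log units; that floor lies within the scatter), and chloro and ethoxy therefore cannot be ordered.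

Going by these compounds, it remains open whether this weakening belongs to chloro alone or would also appear with fluoro, bromo, an amine or a carboxylic acid on the same carbon. On these data alone, how far compound 4 truly lies from the other compounds also stays open.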